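The source may hold more compounds than are shown below. What is called first, only, known or untested is meant among the compounds shown, and "the series" means these compounds.

Values in a functional assay on U-937 cells (Homo sapiens) for antiproliferative activity, read by MTT assay, with a stated time of 24 h; on this read-out lower numbers stand for stronger inhibition and higher numbers for weaker inhibition:
- compound 1 `CCCCc1oc2ccccc2c1C(=O)c1ccc(OCC(=O)N2CCCCC2)cc1`: 37100 nM
- compound 2 `CCCCc1oc2ccccc2c1C(=O)c1ccc(OCCCC(=O)N2CCCC2)cc1`: 7500 nM
- compound 3 `CCCCc1oc2ccccc2c1C(=O)c1ccc(OCCCC(=O)N2CCOCC2)cc1`: 21400 nM

Compound 3 stands with the higher pair of numbers: a 1.7-fold lower number from compound 1 to compound 3 (0.24 log units; within the scatter), whereas a 2.9-fold higher number from compound 2 to compound 3 (0.46 log units; beyond the scatter).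

Compound 4 `CCCCc1oc2ccccc2c1C(=O)c1ccc(OCCCC(=O)N[C@@H](C)c2ccccc2)cc1` has (1-phenylethyl)amino in place of morpholin-4-yl on a carbonyl carbon. The only measured step at this carbonyl carbon is the modest one from compound 2 to compound 3 given above. The step of a 4.9-fold lower number from compound 1 to compound 2 (0.69 log units; beyond the scatter) also alters the chain, so it bears less directly. Among the measured compounds shown here, no measured compound carries (1-phenylethyl)amino, so the size remains uncertain.

A modest move to a lower number in this assay is expected. The expected step is a 1.9-fold lower number from compound 3 to compound 4 (0.29 log units; within the scatter). For compound 4 the estimated value is 11000 nM, with an expected range of 3500 nM to 35000 nM.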

Compound 4, half-maximal inhibitory concentration: 22400 nM
Compound 4: the middle estimate sits 2.0-fold (0.31 log units) below what was measured; low and high end bracket the measured number.
By their numbers in this assay, from the lowest: compound 2; then compounds 3, 4 and 1 (each within the scatter of the next).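

In this assay, (1-phenylethyl)amino on this carbonyl carbon gives a 1.0-fold higher number from compound 3 to compound 4 (0.02 log units; within the scatter), so the exchange for morpholin-4-yl, despite the added aromatic ring, amide hydrogen and defined stereocentre, separates nothing. With a 3.0-fold higher number from compound 2 to compound 4 (0.48 log units; beyond the scatter) beside a 2.9-fold higher number from compound 2 to compound 3 (0.46 log units; beyond the scatter), pyrrolidin-1-yl now stands apart from two different groups at this place on the same chain. Nothing available accounts for this result. Open, as far as these compounds go, is whether the opposite stereocentre of (1-phenylethyl)amino, or benzylamino, would differ from compound 4. Also open, from the compounds shown here alone, is whether piperidin-1-yl on this same chain would stay with compound 2 or with compound 3.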